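Moving the Methoxy Group Around the Benzyl Ring

The compounds below may be only part of what the source reports. "The series", "measured", "known", "first", "only" and "open" are said of these compounds alone.

Three sulfonamides built on one shared core have been tested in a functional assay on ASPC1 cells (Homo sapiens) for inhibition, read by MTT assay, with a stated time of 72 h; on this read-out lower numbers stand for stronger inhibition of growth and higher numbers for weaker inhibition of growth. Compound 1 `O=S(=O)(NCCCNCc1ccc(Cl)cc1)c1cc(C(F)(F)F)cc(C(F)(F)F)c1` gives 3000 nM, compound 2 `O=S(=O)(NCCCNCc1ccc(C(F)(F)F)cc1)c1cc(C(F)(F)F)cc(C(F)(F)F)c1` gives 2000 nM, and compound 3 `COc1ccccc1CNCCCNS(=O)(=O)c1cc(C(F)(F)F)cc(C(F)(F)F)c1` gives 4600 nM. Compound 3 therefore holds the highest number of the three: one of the two steps ending there reads a 2.3-fold higher number from compound 2 to compound 3 (0.36 log units; beyond the scatter), whereas the other reads only a 1.5-fold higher number from compound 1 to compound 3 (0.19 log units; within the scatter). Compound 4 `COc1ccc(CNCCCNS(=O)(=O)c2cc(C(F)(F)F)cc(C(F)(F)F)c2)cc1` awaits measurement; it differs from compound 3 by 4-methoxyphenyl in place of 2-methoxyphenyl on a saturated chain carbon bound to an amine nitrogen. Among the compounds with values here, no measured step moves a methoxy group, so the bearing steps are the two that end at compound 3, both of which ran toward a higher number. Reversing that direction, a small expected step of a 1.5-fold lower number from compound 3 to compound 4 (0.19 log units; within the scatter) seems reasonable. Compound 4 is accordingly estimated at 3000 nM, within a range from 1500 nM to 6500 nM.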

Compound 4, concentration for 50% growth inhibition: 2800 nM
Estimate against measurement, compound 4: 1.1-fold (0.03 log units) above, within the range that was stated.
By their numbers in this assay, from the lowest: compounds 2, 4, 1 and 3 (each within the scatter of the next, the first and the last beyond it).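

Moving the methoxy group, with the same atoms kept, gives a 1.6-fold lower number from compound 3 to compound 4 (0.22 log units; within the scatter) in this assay, so the place of this group on the ring makes no difference that can be told from scatter here. With the 4-methoxyphenyl in place, the comparisons with the other two ring groups read a 1.4-fold higher number from compound 2 to compound 4 (0.15 log units; within the scatter) and a 1.1-fold lower number from compound 1 to compound 4 (0.03 log units; within the scatter), and so methoxy, trifluoromethyl and chloro cannot be told apart at that ring position. Nothing available explains these numbers.

As far as these compounds go, whether a hydroxy group or an amine on that ring, or a longer chain, would move the number beyond the scatter remains open.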